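The source may hold more compounds than are shown below. What is called first, only, known or untested is meant among the compounds shown, and "the series" means these compounds.

Measured in a functional assay on K562 cells (Homo sapiens) for cytotoxicity, read by trypan blue exclusion, with a stated time of 96 h; a higher number here means a weaker inhibitor, a lower number a stronger inhibitor:
compound 1 `COC(=O)C(F)(F)Nc1cc(CS(=O)(=O)/C=C/c2c(OC)cc(OC)cc2OC)ccc1OC`: 250 nM
compound 2 `COC(=O)C(Nc1cc(CS(=O)(=O)/C=C/c2c(OC)cc(OC)cc2OC)ccc1OC)c1ccc(F)cc1`: 800 nM
compound 3 `COC(=O)C(Nc1cc(CS(=O)(=O)/C=C/c2c(OC)cc(OC)cc2OC)ccc1OC)c1ccc(Cl)cc1`: 200 nM

On these numbers, compound 3 shares its standing with the difluoro ester, as the data show a 1.3-fold lower number from compound 1 to compound 3 (0.10 log units; within the scatter). The gap to the fluoro analogue is clearer, at a 4.0-fold lower number from compound 2 to compound 3 (0.60 log units; beyond the scatter).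

Compound 4 `COC(=O)C(Nc1cc(CS(=O)(=O)/C=C/c2c(OC)cc(OC)cc2OC)ccc1OC)c1ccc(Br)cc1` makes one further change: bromo in place of chloro on an aromatic carbon. This places bromo in place of chloro on an aromatic carbon, para to a large group.

Among the compounds with values here, the closest precedent is the only measured halogen swap at this position, a 4.0-fold lower number from compound 2 to compound 3 (0.60 log units; beyond the scatter), a modest step. The other measured steps, a 3.2-fold higher number from compound 1 to compound 2 (0.51 log units; beyond the scatter) and a 1.3-fold lower number from compound 1 to compound 3 (0.10 log units; within the scatter), replace the whole group on the nitrogen and bear on this change only loosely. One swap cannot establish a trend, so only a small continuation in the same direction is expected in this assay, probably not beyond the scatter. The expected change is a 1.3-fold lower number from compound 3 to compound 4 (0.12 log units; within the scatter). For compound 4 the estimated value is 150 nM, with an expected range of 60 nM to 400 nM.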

Compound 4, half-maximal inhibitory concentration: 200 nM
The estimate for compound 4 lay 1.3-fold (0.12 log units) below the measured number; the measured number falls inside the stated range.
By their numbers in this assay, from the lowest: compounds 3, 4 and 1 (each within the scatter of the next); then compound 2.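

In this assay the change from chloro to bromo gives no change at the digits printed from compound 3 to compound 4 (within the scatter) and so does not continue the earlier gain from fluoro to chloro at this place. Bromo and chloro stand level here, and the step from fluoro to bromo gives a 4.0-fold lower number from compound 2 to compound 4 (0.60 log units; beyond the scatter) so that, of the three halogens, only fluoro stands apart. Replacing the difluoro(methoxycarbonyl)methyl group with (4-bromophenyl)(methoxycarbonyl)methyl gives a 1.3-fold lower number from compound 1 to compound 4 (0.10 log units; within the scatter) and leaves compound 4 level with compound 1.

Nothing among the data explains why fluoro differs from the two larger halogens. Still open, going by these compounds, is whether iodo, methyl, methoxy or a bare hydrogen at this place would stay level with compound 3 and compound 4 or fall with compound 2.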